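Methylating the Phenol of Compound 3: an Expected Binding Shift

The source may report more compounds than this note shows. Statements on the series, on what has been measured and on what is new or still open speak of the compounds shown alone.

Compound 1 `Oc1cccc2c1CCCC2c1c[nH]cn1` gives an inhibition constant of 145 nM in an assay on isolated protein (Cricetulus griseus) for binding affinity to Alpha-1B adrenergic receptor (Mesocricetus auratus), read by radioligand binding; a higher number here means a weaker inhibitor, a lower number a stronger inhibitor. Compound 2 `COc1ccc2c(c1NS(C)(=O)=O)CCCC2c1c[nH]cn1` gives 1700 nM in this assay. For compound 3 `CS(=O)(=O)Nc1ccc(O)c2c1CCCC2c1c[nH]cn1` this assay reports only a limit, < 10000 nM, not a number. Compound 3 therefore stands at the limit of < 10000 nM in this assay, at which 1 of the 3 values shown sits, with no firm value of its own. Compound 4 `COc1ccc(NS(C)(=O)=O)c2c1C(c1c[nH]cn1)CCC2` has not been measured; it differs from compound 3 by methyl in place of hydrogen on an oxygen on an aromatic ring. Among the compounds with values here, no single-change step between measured compounds is available, so the size of this change is open. Compound 2, which also carries a methoxy group, gives 1700 nM. The step that the limit leaves unreadable from compound 3 to compound 4 is expected to move from the limit to a measurable, moderate value. Compound 4 is estimated at 2000 nM, within 300 nM to 10000 nM.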

Compound 4, inhibition constant: < 10000 nM
Compound 4 was reported as a limit; the forecaster's own chance of this, stated with the estimate: 25%; the middle value does not contradict the limit.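

Compound 3 and compound 4 are both reported only as limits, so no step from hydroxy to methoxy can be read between them: the limit of < 10000 nM in this assay, at which 2 of the 4 values shown sit.

The compounds shown leave open how far, or whether, this change shifts binding in this assay.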